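The source may report more compounds than this note shows. Statements on the series, on what has been measured and on what is new or still open speak of the compounds shown alone.

Among the measured compounds shown here, in a functional assay on DU-145 cells (Homo sapiens) for cytotoxicity, read by MTT assay, with a stated time of 48 h (on this read-out higher numbers stand for weaker inhibition and lower numbers for stronger inhibition), compound 2 `COc1ccc(-c2cc(C(=O)Nc3nc4ccc(Cl)cc4s3)nc3cc(-c4ccccc4)nn23)cc1OC` gives 9330 nM, the higher of the two numbers measured so far; its neighbour compound 1 `COc1ccc(-c2cc(C(=O)Nc3nc4ccc(Cl)cc4s3)nc3cc(-c4ccccc4)nn23)cc1` gives 5880 nM, and the step of a 1.6-fold higher number from compound 1 to compound 2 (0.20 log units; within the scatter) lies within the scatter. Compound 3 `COc1ccc2nc(NC(=O)c3cc(-c4ccc(OC)c(OC)c4)n4nc(-c5ccccc5)cc4n3)sc2c1` differs from compound 2 by methoxy in place of chloro on an aromatic carbon. For the measured compounds named here, no measured step concerns this change; the only step seen, the methoxy added from compound 1 to compound 2, stayed within the scatter. A step of a 1.0-fold lower number from compound 2 to compound 3 (0.02 log units; within the scatter) is therefore expected, none beyond the scatter. Compound 3 is estimated at 9000 nM, within 3000 nM to 27000 nM.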

Compound 3, half-maximal inhibitory concentration: 14000 nM
Compound 3: the middle estimate sits 1.6-fold (0.19 log units) below what was measured; the range from low to high includes it.
By their numbers in this assay, from the lowest: compounds 1, 2 and 3 (each within the scatter of the next, the first and the last beyond it).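

Exchanging 6-chloro-1,3-benzothiazol-2-yl for 6-methoxy-1,3-benzothiazol-2-yl in this assay gives a 1.5-fold higher number from compound 2 to compound 3 (0.18 log units; within the scatter), so this exchange at this position cannot be told apart from the scatter. Unlike the earlier step of a 1.6-fold higher number from compound 1 to compound 2 (0.20 log units; within the scatter), which lay elsewhere in the molecule, this one shows that the read-out holds within the scatter when this substituent is changed as well. No measured evidence bears on this result.

As far as these compounds go, whether an amine or a carboxylic acid at this position would also stay within the scatter remains open. So does the outcome with hydrogen there.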